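The compounds below may be only part of what the source reports. "The series", "measured", "known", "first", "only" and "open" are said of these compounds alone.

For the measured compounds named here, in a functional assay on A549 cells (Homo sapiens) for antiproliferative activity, read by MTT assay, with a stated time of 72 h (on this read-out lower numbers stand for stronger inhibition and higher numbers for weaker inhibition), compound 1 `CN1CCN(C(=S)SCc2ccc3nc(N)nc(N)c3c2)CC1` gives 9200 nM, while compound 2 `Nc1nc(N)c2cc(CSC(=S)N3CCN(c4ccc([N+](=O)[O-])cc4)CC3)ccc2n1` gives 1910 nM, the lower of the two numbers so far. Compound 3 `Nc1nc(N)c2cc(CSC(=S)N3CCN(c4ncccn4)CC3)ccc2n1` has not yet been measured and differs from compound 2 at one place: pyrimidin-2-yl in place of 4-nitrophenyl on an amine nitrogen in a ring. The change is pyrimidin-2-yl in place of 4-nitrophenyl on an amine nitrogen in a ring.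

Going by the values given here, one measured step bears on this place: a 4.8-fold lower number from compound 1 to compound 2 (0.68 log units; beyond the scatter), a modest change with 4-nitrophenyl in place of methyl. Among the compounds with values here, no measured compound carries an aromatic ring with hetero atoms here, so the expectation rests on that single step. A modest move toward higher numbers in this assay is expected, recovering part of that step, though a result within the scatter remains possible. The expected step is a 2.1-fold higher number from compound 2 to compound 3 (0.32 log units; beyond the scatter). The estimate for compound 3 is 4000 nM, with an expected range of 1500 nM to 11000 nM.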

Compound 3, half-maximal inhibitory concentration: 4010 nM
Compound 3: middle estimate off by 1.0-fold (0.00 log units), on the low side; the range from low to high includes it.
By their numbers in this assay, from the lowest: compound 2; then compound 3; then compound 1.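

In this assay, the change to pyrimidin-2-yl gives a 2.1-fold higher number from compound 2 to compound 3 (0.32 log units; beyond the scatter), so 4-nitrophenyl keeps the lowest number of the three groups on this amine nitrogen in a ring. The lower number relative to methyl is not confined to 4-nitrophenyl, since the aromatic ring with hetero atoms also gives a 2.3-fold lower number from compound 1 to compound 3 (0.36 log units; beyond the scatter), placing pyrimidin-2-yl between the other two groups in the order of values. No measured evidence accounts for this order.

Open, as far as these compounds go, is where a plain phenyl, a benzyl or a longer alkyl chain on this nitrogen would fall relative to these three groups, and a plain phenyl would help separate the contribution of the nitro group from that of the carbon-only ring. Also open, from the compounds shown here alone, is whether the same order holds on cell lines other than the one used here.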